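This account rests on a few compounds, and the source may have more. Where it says the series, first, only, none or still open, it means among the compounds named here.

Among the compounds with values here, compound 2 `Nc1cccc(Nc2c(C(=O)NCc3ccc(F)cc3)nc(Br)c3cccnc23)c1` is the only compound here with a number: in a functional assay on MCF7 cells (Homo sapiens) for cytotoxicity, read by MTT assay, with a stated time of 72 h (a higher number here means a weaker inhibitor, a lower number a stronger inhibitor), compound 2 gives 8000 nM. For compound 1 `O=C(NCc1ccc(F)cc1)c1nc(NCCO)c2cccnc2c1O` the result in this assay is "not determined" (no result reported), so there is no second measured point to set a scale for any step. Compound 3 `NCCNc1c(C(=O)NCc2ccc(F)cc2)nc(Br)c2cccnc12` differs from compound 2 in one place: 2-aminoethyl in place of 3-aminophenyl on a nitrogen on an aromatic ring. With nothing measured to anchor this exchange, no step beyond the usual scatter is expected from compound 2 to compound 3 in this assay, so the expected step is a 1.1-fold higher number from compound 2 to compound 3 (0.05 log units; within the scatter). Compound 3 is therefore estimated at 9000 nM, with a range from 2500 nM to 35000 nM.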

Compound 3, half-maximal inhibitory concentration: 6000 nM
The estimate for compound 3 lay 1.5-fold (0.18 log units) above the measured number; low and high end bracket the measured number.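

A step of a 1.3-fold lower number from compound 2 to compound 3 (0.12 log units; within the scatter) in this assay gives this exchange its first measured scale. On a nitrogen on an aromatic ring, the 3-aminophenyl with its six-membered aromatic ring and the 2-aminoethyl with no ring give numbers that cannot be told apart. No measured evidence here bears on this result. Still open, on these data alone, is whether a longer chain such as 3-aminopropyl, or a carboxylic acid in place of the amine, would shift the number at this nitrogen. Open too, as far as these compounds go, is whether a plain phenyl, with no amine, would do so.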